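The compounds below may be only part of what the source reports. "The series", "measured", "known", "first", "only" and "open" are said of these compounds alone.

Measured so far in a functional assay on MGC-803 cells (Homo sapiens) for inhibition, read by MTT assay, with a stated time of 72 h; a lower number here means a stronger inhibitor, a higher number a weaker inhibitor:
compound 1 `C=CC(=O)Nc1cccc(NC(=O)CSc2nc(Nc3cccc(C)c3)c3ccccc3n2)c1`, 20900 nM
compound 2 `C=CC(=O)Nc1cccc(NC(=O)CSc2nc(Nc3ccc(F)cc3)c3ccccc3n2)c1`, 8290 nM
compound 3 `C=CC(=O)Nc1cccc(NC(=O)CSc2nc(Nc3ccc(Cl)cc3)c3ccccc3n2)c1`, 14300 nM

Compound 3 stands second highest of the three numbers in this assay. Its two neighbours are both within the scatter of it: a 1.5-fold lower number from compound 1 to compound 3 (0.16 log units; within the scatter) and, in the other direction, a 1.7-fold higher number from compound 2 to compound 3 (0.24 log units; within the scatter). For the measured compounds named here, the only step beyond the scatter in the set is a 2.5-fold lower number from compound 1 to compound 2 (0.40 log units; beyond the scatter), which exchanges the whole substituted phenyl rather than a single atom.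

Compound 4 `C=CC(=O)Nc1cccc(NC(=O)CSc2nc(Nc3ccc(Br)cc3)c3ccccc3n2)c1` is the next member. Computed from the two structures, the difference from compound 3 is bromo in place of chloro on an aromatic carbon. The change sits on an aromatic carbon of a six-membered aromatic ring of carbon only, para to a large group.

The step that bears most directly on it is the halogen-for-halogen exchange a 1.7-fold higher number from compound 2 to compound 3 (0.24 log units; within the scatter), which stayed within the scatter. The steps from compound 1 bear only loosely, since they swap a 3-methylphenyl for a 4-halophenyl. On this basis no step beyond the scatter is expected in this assay, in either direction. Compound 4 is therefore estimated at 15000 nM, with a range of 6000 nM to 38000 nM. The expected step is a 1.0-fold higher number from compound 3 to compound 4 (0.02 log units; within the scatter).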

Compound 4, half-maximal inhibitory concentration: 11500 nM
Compound 4: middle estimate off by 1.3-fold (0.12 log units), on the high side; low and high end bracket the measured number.
By their numbers in this assay, from the lowest: compounds 2, 4, 3 and 1 (each within the scatter of the next, the first and the last beyond it).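

Notes on the series: with bromo added, the 4-halophenyl position carries three halogens, and in this assay none of the halogen-for-halogen steps leaves the scatter (a 1.7-fold higher number from compound 2 to compound 3 (0.24 log units; within the scatter); a 1.2-fold lower number from compound 3 to compound 4 (0.09 log units; within the scatter); a 1.4-fold higher number from compound 2 to compound 4 (0.14 log units; within the scatter)), so the compounds shown do not separate fluoro, chloro and bromo at this position. Compound 4 also stays within the scatter of the 3-methylphenyl compound (a 1.8-fold lower number from compound 1 to compound 4 (0.26 log units; within the scatter)), as does compound 3, which leaves compound 2 as the only one of the three halogen compounds with a step beyond the scatter (a 2.5-fold lower number from compound 1 to compound 2 (0.40 log units; beyond the scatter)); a general separation of 4-halophenyl from 3-methylphenyl therefore does not hold, with compound 3 and compound 4 going against it. No measurement at hand gives a reason for these numbers.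

Going by these compounds, what a group other than a halogen at this position would do, such as a methoxy group, an amine or a carboxylic acid, remains open. Also open, on these data alone, is whether the number in this assay depends on the acrylamide, for instance with a saturated propionamide in its place on the shared core.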